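Trading a Pentyl Tail for Phenyl at the Chain End

This account rests on a few compounds, and the source may have more. Where it says the series, first, only, none or still open, it means among the compounds named here.

Compound 1 `CCCCCCCCOc1ccc2c(Cl)ccnc2c1` carries the higher of the two numbers recorded in a functional assay on HepG2 cells (Homo sapiens) for cytotoxicity, read by MTT assay, with a stated time of 48 h; a lower number here means a stronger inhibitor, a higher number a weaker inhibitor: compound 1 gives 2640 nM, and compound 2 `C=CCOc1ccc2c(NCCN(C)C)ccnc2c1` gives 1660 nM, a gap that falls within the usual scatter. Compound 3 `Clc1ccnc2cc(OCCCc3ccccc3)ccc12` differs from compound 1 in a single place: phenyl in place of pentyl on a saturated chain carbon, three bonds along the chain from an oxygen on an aromatic ring. For the measured compounds named here, no measured pair shows this change, so the step from compound 1 to compound 3 is expected to be a 1.1-fold lower number from compound 1 to compound 3 (0.02 log units; within the scatter), small and of uncertain direction, not clearly beyond the scatter. Compound 3 is therefore estimated at 2500 nM, within a range from 800 nM to 8000 nM.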

Compound 3, half-maximal inhibitory concentration: 1780 nM
Beside the measured number, compound 3's estimate is 1.4-fold (0.15 log units) above it, within the range that was stated.
By their numbers in this assay, from the lowest: compounds 2, 3 and 1 (each within the scatter of the next).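

In this assay the swap of pentyl for phenyl gives a 1.5-fold lower number from compound 1 to compound 3 (0.17 log units; within the scatter) and so leaves the number within the scatter. At this place on the chain, a six-membered aromatic ring can therefore replace an open pentyl tail without a clear change, which the earlier pair, differing in more than one place, could not show. Nothing available explains this result. Going by these compounds, it remains open whether a carboxylic acid or a cyclohexyl ring at the chain end would move the number beyond the scatter. On these data alone, it also remains open whether the same swap would give a similar result on another core.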